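This account rests on a few compounds, and the source may have more. Where it says the series, first, only, none or still open, it means among the compounds named here.

Measured so far in an assay on cells for agonist activity at ecdysone receptor (Bombyx mori), read by a luciferase reporter, with a stated time of 24 h; a higher number here means that more compound is needed for the effect, a lower number that less compound is needed:
compound 1 `CC(C)(C)N(NC(=O)c1ccccc1Cl)C(=O)c1ccccc1Cl` gives 331 nM
compound 2 `Cc1ccccc1C(=O)NN(C(=O)c1ccccc1Cl)C(C)(C)C` gives 72.4 nM
compound 3 `Cc1ccc(C(=O)NN(C(=O)c2ccccc2Cl)C(C)(C)C)cc1` gives 18.6 nM

Compound 1 stands at the highest number of the three. The step to compound 4 `Cc1cccc(C(=O)NN(C(=O)c2ccccc2Cl)C(C)(C)C)c1C` is 2,3-dimethylphenyl in place of 2-chlorophenyl on a carbonyl carbon. Among the measured compounds shown here, two measured steps bear on it: a 4.6-fold lower number from compound 1 to compound 2 (0.66 log units; beyond the scatter), and an 18-fold lower number from compound 1 to compound 3 (1.25 log units; beyond the scatter). Both exchange the chloro-bearing ring on that carbonyl carbon for a methyl-bearing one, and both lower the number beyond the scatter; the further step a 3.9-fold lower number from compound 2 to compound 3 (0.59 log units; beyond the scatter) shows that where the methyl sits matters. Compound 4 carries two methyls, one placed as in compound 2, so a modest lowering is expected, a 6.0-fold lower number from compound 1 to compound 4 (0.78 log units; beyond the scatter), and compound 4 is estimated at 55 nM, between 15 nM and 200 nM.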

Compound 4, half-maximal effective concentration: 20 nM
Estimate against measurement, compound 4: 2.8-fold (0.44 log units) above; measured number inside the range.
By their numbers in this assay, from the lowest: compounds 3 and 4 (each within the scatter of the next); then compound 2; then compound 1.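

In this assay, a second methyl on the ring still counts, with a 3.6-fold lower number from compound 2 to compound 4 (0.56 log units; beyond the scatter). The 2,3-dimethylphenyl group thus matches the 4-methylphenyl group, with a 1.1-fold higher number from compound 3 to compound 4 (0.03 log units; within the scatter), and the full exchange of 2-chlorophenyl gives a 17-fold lower number from compound 1 to compound 4 (1.22 log units; beyond the scatter), so keeping one methyl where compound 2 has it does not prevent a low number. Nothing measured here explains this.

The compounds shown leave open whether a methoxy or an ethyl on this ring would act as the methyl does. They also leave open how a ring carrying two chloro groups would compare.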